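Swapping a Chlorobenzyl for a Phenylsulfonyl Group on Two Cores

The compounds below may be only part of what the source reports. "The series", "measured", "known", "first", "only" and "open" are said of these compounds alone.

Compound 1 `C#CCNC1CCc2c(OCCCCN3CCN(c4cccc5c4ccn5Cc4cccc(Cl)c4)CC3)cccc21` and compound 2 `C#CCNC1CCc2c(OCCCCN3CCN(c4cccc5c4ccn5S(=O)(=O)c4ccccc4)CC3)cccc21` share one core and differ in a single place: phenylsulfonyl in place of 3-chlorobenzyl on an aromatic nitrogen. In an assay on BTI cells for inhibition of Amine oxidase [flavin-containing] B (Homo sapiens), read by fluorescence, with stated times of 30 min and 1 h, tested at 1 uM (a lower number here means less inhibition, a higher number more inhibition at the concentration tested (going by the name of the read-out)), compound 1 gives 100%, while compound 2 gives 44%, so this change brought a number 56 percentage points lower from compound 1 to compound 2 (beyond the scatter).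

Compound 3 `C[C@H](NCc1ccc(OCCCCN2CCN(c3cccc4c3ccn4Cc3cccc(Cl)c3)CC2)cc1)C(N)=O` carries the same 3-chlorobenzyl group on an aromatic nitrogen of the same kind, but on a different core; the difference between the core of compound 1 and the core of compound 3 is not broken down here. In this assay compound 3 gives 24%, the lowest of the three measured numbers, beyond the scatter below both compound 2 and compound 1.

Compound 4 `C[C@H](NCc1ccc(OCCCCN2CCN(c3cccc4c3ccn4S(=O)(=O)c3ccccc3)CC2)cc1)C(N)=O` is the unmeasured partner of compound 3: phenylsulfonyl in place of 3-chlorobenzyl on an aromatic nitrogen. Its place is word for word the same as in the pair of compound 1 and compound 2, so it is the same change made a second time; it occurs twice among these compounds. The first occurrence cut the read-out deeply, and the expectation rests on that one step together with the low starting point of compound 3.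

The expected step is a number 16 percentage points lower from compound 3 to compound 4 (beyond the scatter), smaller than a number 56 percentage points lower from compound 1 to compound 2 (beyond the scatter) because compound 3 begins at 24%, leaving little room to fall. For compound 4 an inhibition of 8% is estimated in this assay, in a range from 0% to 25%.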

Compound 4, a percentage reported as inhibition, at one concentration (the size of the read-out at that concentration, not a potency): 20%
Compound 4: the middle estimate sits 12 percentage points below what was measured, within the range that was stated.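

On the core of compound 3, in this assay, phenylsulfonyl in place of 3-chlorobenzyl on an aromatic nitrogen gives a number 4 percentage points lower from compound 3 to compound 4 (within the scatter), so the deep cut seen on the core of compound 1 does not reappear here. The change therefore does not carry over in size from one core to the other: the same change on two cores in this assay, a number 56 percentage points lower (beyond the scatter) from compound 1 to compound 2 and a number 4 percentage points lower (within the scatter) from compound 3 to compound 4, 52 percentage points apart, beyond the scatter of two such steps. Within the data shown here, this shows that, in these two pairs, the step taken on one core does not predict the step on the other, but it does not show which part of the cores sets the difference, and with only two pairs and a read-out at a single concentration it gives no general rule for the series.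

From the compounds shown here alone, it remains open whether a methyl or a benzoyl group on the same aromatic nitrogen would follow the pattern of the core of compound 1 or that of the core of compound 3. Going by these compounds, it is also open whether a third core, for instance one with a longer chain in place of the present butyl-type linker, would show a large step, a small step or something in between.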